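Replacing a branched chain by a cyclohexylmethyl group

A few compounds are considered here, and "the series" means these few. Any claim that something is new, unique, unknown or untested is made for them only; others in the source may bear on it.

Compound 3 `CCCCC(CCCC)C(O/N=C(\C)C(=O)O)c1ccc(OCc2ccc3ccccc3n2)cc1` gives 14 nM in a functional assay for inhibition of Polyunsaturated fatty acid 5-lipoxygenase (Homo sapiens) (on this read-out higher numbers stand for weaker inhibition and lower numbers for stronger inhibition), the second highest of the three numbers recorded. Its closest neighbour is compound 2 `CCCCC(CCCC)C(O/N=C/C(=O)O)c1ccc(OCc2ccc3ccccc3n2)cc1`, which gives 10 nM, and the step of a 1.4-fold higher number from compound 2 to compound 3 (0.15 log units; within the scatter) alters only the group on the oxime oxygen. Compound 1 `O=C(O)/C(=N/OC(c1ccc(OCc2ccc3ccccc3n2)cc1)C1CCCCC1)c1ccccc1` gives 31 nM, a number beyond the scatter from compound 3. Compound 4 `C/C(=N\OC(CC1CCCCC1)c1ccc(OCc2ccc3ccccc3n2)cc1)C(=O)O` carries cyclohexylmethyl in place of 1-butylpentyl on a saturated chain carbon bound to an aromatic carbon and an oxygen on an unsaturated carbon. Among the measured compounds shown here, no measured step changes this position alone; compound 1 differs from compound 4 in two places, so only its value can be consulted. The expected step is therefore a 1.4-fold higher number from compound 3 to compound 4 (0.15 log units; within the scatter), a small weakening at most. Compound 4 is accordingly estimated at 20 nM, with a range from 8 nM to 50 nM.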

Compound 4, half-maximal inhibitory concentration: 29 nM
Estimate against measurement, compound 4: 1.5-fold (0.16 log units) below; measured number inside the range.
By their numbers in this assay, from the lowest: compounds 2 and 3 (each within the scatter of the next); then compounds 4 and 1 (each within the scatter of the next).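

In this assay, among the compounds shown here, cyclohexylmethyl in place of 1-butylpentyl gives a 2.1-fold higher number from compound 3 to compound 4 (0.32 log units; beyond the scatter), the first measured change at this position. The step is modest but lies beyond the scatter, so the number does respond to exchanging this open chain for a ring-bearing group with fewer heavy atoms. Nothing available bears on why the number rises.

Still open, as far as these compounds go, is how a phenyl group or a plain butyl chain on this same carbon would read. From the compounds shown here alone, it is also open whether the same exchange would give a similar step on the side chain of compound 2.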